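Furan-2-yl Replacing Dimethylaminophenyl on the Indoline Sulfonamide Core

The source may report more compounds than this note shows. Statements on the series, on what has been measured and on what is new or still open speak of the compounds shown alone.

Compound 1 `COc1ccc(S(=O)(=O)N2CCc3cccc(-c4ccc(F)c(F)c4)c32)cc1`: 55.5 nM
Compound 2 `COc1ccc(S(=O)(=O)N2CCc3cccc(-c4ccc(N(C)C)cc4)c32)cc1`: 237 nM
Compound 3 `COc1ccc(S(=O)(=O)n2ccc3cccc(-c4ccc(C#N)cc4)c32)cc1`: 143 nM

In a functional assay on MKN-45 cells (Homo sapiens) for inhibition, with a stated time of 72 h (a higher number here means a weaker inhibitor, a lower number a stronger inhibitor), compound 2 gives the highest of the three numbers. Its nearest neighbour is compound 3, which gives 143 nM, a gap within the scatter; the furthest is compound 1 with 55.5 nM, a gap beyond the scatter. Compound 4 `COc1ccc(S(=O)(=O)N2CCc3cccc(-c4ccco4)c32)cc1` differs from compound 2 in one place: furan-2-yl in place of 4-(dimethylamino)phenyl on an aromatic carbon.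

For the measured compounds named here, only one measured step bears on this change, and only indirectly: a 4.3-fold higher number from compound 1 to compound 2 (0.63 log units; beyond the scatter). That step shows that replacing the aryl group on this position of the shared core can move the number well beyond the scatter. Going by the values given here, no measured step involves furan-2-yl itself, and compound 3 differs from compound 2 in more than one place, so its value serves only as a rough neighbour.

For compound 4 the expectation is a modest step downward, a 2.0-fold lower number from compound 2 to compound 4 (0.30 log units; within the scatter), since compound 1 gives 55.5 nM with a different aryl group in the same place. Compound 4 is therefore estimated at 120 nM, with a range from 40 nM to 360 nM.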

Compound 4, half-maximal inhibitory concentration: 42 nM
For compound 4 the middle estimate is 2.9-fold (0.46 log units) above the measured one; low and high end bracket the measured number.
By their numbers in this assay, from the lowest: compounds 4 and 1 (each within the scatter of the next); then compounds 3 and 2 (each within the scatter of the next).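

Furan-2-yl in place of 4-(dimethylamino)phenyl gives a 5.6-fold lower number from compound 2 to compound 4 (0.75 log units; beyond the scatter) in this assay, so this place on the shared core accepts a five-membered aromatic ring with 1 hetero atom, and a six-membered aromatic ring of carbon only is not required for a low number. Against 3,4-difluorophenyl, the same group gives a 1.3-fold lower number from compound 1 to compound 4 (0.12 log units; within the scatter), so the two cannot be told apart in this assay despite their different rings and heavy-atom counts. Nothing available explains why these groups give the numbers they do.

The compounds shown leave open whether thiophen-2-yl or an unsubstituted phenyl at this place would give numbers like those of compound 1 and compound 4. They also leave open whether furan-2-yl would act the same way on the core of compound 3.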